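From methoxy to trifluoromethyl in compound 4

A few compounds are considered here, and "the series" means these few. Any claim that something is new, unique, unknown or untested is made for them only; others in the source may bear on it.

In an ADME assay on L02 cells (Homo sapiens) for cytotoxicity, read by MTT assay, with a stated time of 24 h (a higher number here means a weaker inhibitor, a lower number a stronger inhibitor), compound 1 `COc1ccc(/C=C2\CN(C)C/C(=C\c3ccccc3F)C2=O)cc1` gives 22100 nM. That value lies within the scatter of compound 3 `COc1cc(/C=C2\CN(C)C/C(=C\c3ccccc3F)C2=O)cc(OC)c1OC` at 12100 nM, while compound 2 `COc1ccc(/C=C2\CN(C)C/C(=C\c3ccccc3F)C2=O)cc1OC` gives 10500 nM. Compound 4 `CN1C/C(=C\c2ccc(C(F)(F)F)cc2)C(=O)/C(=C/c2ccccc2F)C1` differs from compound 1 by a single swap: trifluoromethyl in place of methoxy on an aromatic carbon, para to a large group (trifluoromethyl in place of methoxy on an aromatic carbon). The nearest measured changes each put methoxy in place of hydrogen instead. The step of a 2.1-fold lower number from compound 1 to compound 2 (0.32 log units; beyond the scatter) is modest, and the step of a 1.2-fold higher number from compound 2 to compound 3 (0.06 log units; within the scatter) stays within the scatter. Neither is the same swap, so they offer only weak guidance, and no shift beyond the scatter is expected. The estimated change is a 1.4-fold lower number from compound 1 to compound 4 (0.14 log units; within the scatter). For compound 4 the expected value is 16000 nM, with an estimated range from 7000 nM to 35000 nM.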

Compound 4, half-maximal inhibitory concentration: 18600 nM
Compound 4: middle estimate off by 1.2-fold (0.07 log units), on the low side; low and high end bracket the measured number.
By their numbers in this assay, from the lowest: compounds 2, 3, 4 and 1 (each within the scatter of the next, the first and the last beyond it).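

In this assay, trifluoromethyl in place of methoxy on the aromatic carbon para to a large group gives a 1.2-fold lower number from compound 1 to compound 4 (0.07 log units; within the scatter). The earlier compounds shown here only added methoxy groups, whereas this step replaces the methoxy of compound 1 with a group that has more heavy atoms and no hydrogen-bond acceptor, and the number stays within the scatter. Nothing available here explains this result. Going by these compounds, whether an amine or a carboxylic acid at this position would shift the number beyond the scatter remains open. So does whether the same swap would behave alike in compound 2 or compound 3 .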